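The source may report more compounds than this note shows. Statements on the series, on what has been measured and on what is new or still open speak of the compounds shown alone.

Of the compounds shown here, two have been measured in a functional assay on HEK293 cells for agonist activity at D(4) dopamine receptor (Homo sapiens), read by FLIPR; on this read-out higher numbers stand for an effect only at larger amounts of compound and lower numbers for an effect already at smaller amounts. Compound 1, with the structure `Cc1cccc(NC(=O)CN2CCC(c3ccc(O)cc3)CC2)c1`, gives 70 nM in this assay. Compound 2, with the structure `Cc1cccc(C(=O)NCN2CCC(c3nccs3)CC2)c1`, gives 9.8 nM in this assay. Of the two numbers shown, compound 1 stands at the higher one, and its distance from compound 2 is beyond the usual scatter; the two structures differ in several places at once, so the two values are all that can be said of them.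

Compound 3, with the structure `Cc1cccc(NC(=O)CN2CCC(c3cccc(F)c3)CC2)c1`, has not yet been measured in this assay. It is built from compound 1 by a single change, (3-fluorophenyl in place of 4-hydroxyphenyl on a saturated ring carbon). Among the compounds with values here, no measured pair in this set shows such a change, so the expected size of the step in this assay rests on compound 1 alone, and the step from compound 1 to compound 3 is expected to be modest and toward a higher number, as a 2.1-fold higher number from compound 1 to compound 3 (0.33 log units; beyond the scatter) expresses. For compound 3 the estimate is 150 nM, with a likely range from 40 nM to 600 nM.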

Compound 3, half-maximal effective concentration: 512 nM
Compound 3: the middle estimate sits 3.4-fold (0.53 log units) below what was measured; measured number inside the range.
By their numbers in this assay, from the lowest: compound 2; then compound 1; then compound 3.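

In this assay, putting 3-fluorophenyl in place of 4-hydroxyphenyl on the saturated ring carbon gives a 7.3-fold higher number from compound 1 to compound 3 (0.86 log units; beyond the scatter), so what this position carries clearly matters to the read-out. The change does two things at once: the entering group has a different atom on its aromatic ring and a different number in its name, and it has no hydrogen-bond donor or acceptor, whereas the leaving group has one of each. Nothing available explains the step or shows which of these differences matters.

Still open, from the compounds shown here alone, is how the step would divide between the atom and its place on the ring, which 4-fluorophenyl and 3-hydroxyphenyl on the same core could separate. Also open, going by these compounds, is how a different group, such as 4-aminophenyl, would read at this position.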